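Cytotoxicity notes on a biaryl series, compounds 1 to 4

The source may report more compounds than this note shows. Statements on the series, on what has been measured and on what is new or still open speak of the compounds shown alone.

Measured so far in an ADME assay on HeLa Rh cells (Homo sapiens) for cytotoxicity, read by microscopy; a lower number here means that less compound is tolerated, a higher number that more compound is tolerated:
compound 1, `COc1cc(CC(O)c2ccc(-c3ccc(C=O)cc3)cc2)c([N+](=O)[O-])cc1OC`: a limit only, > 245000 nM
compound 2, `COc1cc(CC(O)c2ccc(-c3ccc(Cl)cc3)cc2)c([N+](=O)[O-])cc1OC`: 4100 nM
compound 3, `COc1cc(CC(O)c2ccc(-c3cccc(C#N)c3)cc2)c([N+](=O)[O-])cc1OC`: 5200 nM

Compound 3 stands at the higher of the two numbers, with compound 2 nearest, a 1.3-fold higher number from compound 2 to compound 3 (0.10 log units; within the scatter). The steps away from the limit of compound 1 were large, an at least 59-fold lower number from compound 1 to compound 2 (1.77 log units; beyond the scatter) and an at least 47-fold lower number from compound 1 to compound 3 (1.67 log units; beyond the scatter). Compound 4, `COc1cc(CC(O)c2ccc(-c3ccncc3)cc2)c([N+](=O)[O-])cc1OC`, differs from compound 3 by pyridin-4-yl in place of 3-cyanophenyl on an aromatic carbon. Going by the values given here, the only step that joins two numbers, a 1.3-fold higher number from compound 2 to compound 3 (0.10 log units; within the scatter), lies within the scatter, and no measured step introduces a ring nitrogen, so for compound 4 no step beyond the scatter is expected in this assay. Compound 4 is thus expected near 6500 nM, between 2500 nM and 20000 nM, an expected step of a 1.3-fold higher number from compound 3 to compound 4 (0.10 log units; within the scatter).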

Compound 4, half-maximal cytotoxic concentration: > 263000 nM
Compound 4: a limit, no number (the forecaster's own chance of this, stated with the estimate: 10%); middle value at least 40-fold (1.60 log units) from the limit.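

In this assay compound 4 gives only a limit: the limit of > 263000 nM in this assay, at which 1 of the 4 values shown sits.
On this aromatic carbon, para to a large group, pyridin-4-yl gives an at least 50-fold higher number from compound 3 to compound 4 (1.70 log units; beyond the scatter) and an at least 64-fold higher number from compound 2 to compound 4 (1.80 log units; beyond the scatter) in exchange for the aryl groups that carry nitrile and chloro. A biaryl with a ring nitrogen thus joins the formyl compound 1 at the tolerated end of the series, while the steps between those two compounds cannot be read.

Open, from the compounds shown here alone, is whether pyridin-3-yl, or a phenyl ring carrying an amine or a carboxylic acid, behaves in the same way at this position.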